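Dimethylphenyl in Place of Chlorophenyl on the Ketone

The source may hold more compounds than are shown below. What is called first, only, known or untested is meant among the compounds shown, and "the series" means these compounds.

Measured so far in a functional assay on HepG2 cells (Homo sapiens) for antiproliferative activity, read by MTT assay, with a stated time of 48 h; a higher number here means a weaker inhibitor, a lower number a stronger inhibitor:
compound 1, `COc1ccc(/C=C/c2cc(OC)cc(OC)c2/C=C/C(=O)c2ccc(Cl)c(Cl)c2)cc1`: 10.8 ug/mL
compound 2, `COc1ccc(/C=C/c2cc(OC)cc(OC)c2/C=C/C(=O)c2cccc(Cl)c2)cc1`: 9.5 ug/mL

Compound 2 has the lower of the two numbers in this assay, and compound 1 lies only a 1.1-fold lower number from compound 1 to compound 2 (0.06 log units; within the scatter) away, within the scatter. Compound 3, `COc1ccc(/C=C/c2cc(OC)cc(OC)c2/C=C/C(=O)c2ccc(C)c(C)c2)cc1`, differs from compound 2 by 3,4-dimethylphenyl in place of 3-chlorophenyl on a carbonyl carbon. Among the measured compounds shown here, the one measured step, a 1.1-fold lower number from compound 1 to compound 2 (0.06 log units; within the scatter), concerns chloro and hydrogen alone and lies within the scatter; no measured pair exchanges chloro for methyl. Compound 3 is therefore expected to show a step of a 1.1-fold higher number from compound 2 to compound 3 (0.02 log units; within the scatter), no change beyond the scatter. The estimate for compound 3 is 10 ug/mL, within the range 5 ug/mL to 22 ug/mL.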

Compound 3, half-maximal inhibitory concentration: 0.2 ug/mL
Beside the measured number, compound 3's estimate is 50-fold (1.70 log units) above it; the whole stated range lies above it.
By their numbers in this assay, from the lowest: compound 3; then compounds 2 and 1 (each within the scatter of the next).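

In this assay, the group on the carbonyl carbon turns out to be able to shift the number far, which the exchange of chloro for hydrogen did not show: 3,4-dimethylphenyl lowers it sharply, both in place of 3-chlorophenyl (a 48-fold lower number from compound 2 to compound 3 (1.68 log units; beyond the scatter)) and in place of 3,4-dichlorophenyl (a 54-fold lower number from compound 1 to compound 3 (1.73 log units; beyond the scatter)). With one or two chloro groups the number stays within the scatter, so here the large drop appears only with the dimethylphenyl group. Nothing available accounts for the size of this drop. Going by these compounds, whether a single methyl group would suffice remains open, as does the effect of a methoxy, trifluoromethyl or amino group on this phenyl.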